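This account rests on a few compounds, and the source may have more. Where it says the series, first, only, none or still open, it means among the compounds named here.

Measured in a functional assay on PC-3M cells (Homo sapiens) for antiproliferative activity, read by microscopy, with a stated time of 24 h; on this read-out higher numbers stand for weaker inhibition and lower numbers for stronger inhibition:
- Compound 1 `COc1ccc(-c2c(-c3ccc(OC)cc3)n(Cc3ccccc3)c3ncn([C@H]4CC[C@H](OC)CC4)c(=N)c23)cc1`: > 20000 nM (a limit)
- Compound 2 `N=c1c2c(-c3ccccc3)c(-c3ccccc3)n(Cc3ccccc3)c2ncn1CCCN1CCN(c2ccccc2)CC1`: 23400 nM; 23400 nM (2 entries)
- Compound 3 `Cc1c(C)n(Cc2ccccc2)c2ncn([C@H]3CC[C@H](O)CC3)c(=N)c12`: > 20000 nM (a limit)

Compound 1 has no numerical reading, and its entry of > 20000 nM is a limit. It therefore stands on (the limit of > 20000 nM in this assay, at which 2 of the 3 values shown sit). Going by the values given here, compound 2 provides the only actual number in the set.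

The next compound is compound 4 `COc1ccc(-c2c(-c3ccc(OC)cc3)n(Cc3ccccc3)c3ncn(C4CCOCC4)c(=N)c23)cc1`. Its structural change from compound 1 is oxan-4-yl in place of 4-methoxycyclohexyl on an aromatic nitrogen, with the rest of the structure unchanged. Among the compounds with values here, no pair of measured compounds differs in one place only, so the series offers no direct precedent for this change.

In this assay, no step beyond the usual scatter is expected, and no direction is favoured. This expectation rests first on compound 1, whose > 20000 nM is a limit. Within the data shown here, it also draws on compound 2, whose reading of 23400 nM; 23400 nM (2 entries) is the only number available as a guide. The expected step is a step that the limit leaves unreadable from compound 1 to compound 4, and a report of only a limit would be no surprise. For compound 4 the estimated value is 23000 nM, with an expected range of 10000 nM to 50000 nM.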

Compound 4, half-maximal inhibitory concentration: > 20000 nM
Compound 4: a limit, no number (the forecaster's own chance of this, stated with the estimate: 70%); the middle value lies beyond the limit too.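

No step can be read from compound 1 to compound 4 in this assay, as both entries are limits and not numbers: the limit of > 20000 nM in this assay, at which 3 of the 4 values shown sit.

The compounds shown leave open whether oxan-4-yl and 4-methoxycyclohexyl on the aromatic nitrogen differ at all in antiproliferative activity on the shared core.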